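A few compounds are considered here, and "the series" means these few. Any claim that something is new, unique, unknown or untested is made for them only; others in the source may bear on it.

Series notes. The compounds share a common core carrying a substituted aromatic ring: compound 1 `FC(F)(F)c1ccc(/C=C/[C@@H]2CCCCN2)cc1`, compound 2 `Cc1cccc(C)c1/C=C/[C@@H]1CCCCN1`, compound 3 `O=[N+]([O-])c1ccc(/C=C/[C@@H]2CCCCN2)cc1` and the as yet unmeasured compound 4 `Cc1ccc(/C=C/[C@@H]2CCCCN2)cc1`. In a functional assay on OVCAR-3 cells (Homo sapiens) for inhibition, read by MTT assay, with a stated time of 24 h (a lower number here means a stronger inhibitor, a higher number a weaker inhibitor), compound 1 gives 0.99 ug/mL, compound 2 gives 6.27 ug/mL, and compound 3 gives 1.02 ug/mL. Compound 3 thus stands second highest of the three numbers, with compound 1 nearest and compound 2 furthest. For the measured compounds named here, the one measured step, a 1.0-fold higher number from compound 1 to compound 3 (0.01 log units; within the scatter), exchanges one group on the aromatic carbon for another without moving the number. The change to compound 4 is methyl in place of nitro on an aromatic carbon. Going by the values given here, no measured step covers methyl entering in place of nitro, so the expectation rests on two observations: compound 1 and compound 3 sit together within the scatter, while compound 2 and compound 3 are separated beyond it. A moderate rise in this assay is expected, a 2.0-fold higher number from compound 3 to compound 4 (0.29 log units; within the scatter), with wide uncertainty. Compound 4 is therefore estimated at 2 ug/mL, range 0.8 ug/mL to 5 ug/mL.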

Compound 4, half-maximal inhibitory concentration: 8.48 ug/mL
Compound 4: middle estimate off by 4.2-fold (0.63 log units), on the low side; the measured number lies above the stated range.
By their numbers in this assay, from the lowest: compounds 1 and 3 (each within the scatter of the next); then compounds 2 and 4 (each within the scatter of the next).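

In this assay, the position para to a group of 8 heavy atoms proves sensitive to the group it carries: an 8.3-fold higher number from compound 3 to compound 4 (0.92 log units; beyond the scatter), and an 8.6-fold higher number from compound 1 to compound 4 (0.93 log units; beyond the scatter). The earlier step, a 1.0-fold higher number from compound 1 to compound 3 (0.01 log units; within the scatter), therefore does not mean that this position accepts any group; the match holds for nitro and trifluoromethyl, and methyl does not share it. Nothing measured on these compounds accounts for the gap between methyl and the other two groups.

For the compounds shown here, with only three groups compared at this position, it remains open whether a nitrile, an amine or a chlorine atom would sit with nitro and trifluoromethyl or with methyl. Also open, going by these compounds, is how a longer chain such as ethyl, or plain hydrogen, would read at the same carbon.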